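The compounds below may be only part of what the source reports. "The series", "measured", "known", "first", "only" and "open" are said of these compounds alone.

Measured so far:
compound 1, `C=C1C[C@]23C[C@@]1(O)CC[C@@H]2c1cccc(C)c1[C@@H]3Cn1cc(-c2ccc(C)cc2)nn1` — > 20000 nM
compound 2, `C=C1C(=O)[C@]23C[C@@]1(O)CC[C@H]2c1ccc(O)c(C)c1[C@@H]3Cn1cc(-c2ccc(C)cc2)nn1` — 1260 nM
compound 3, `C=C1C[C@]23C[C@@]1(O)CC[C@H]2c1ccc(OS(=O)(=O)c2ccc(C)cc2)c(C)c1[C@@H]3Cn1cc(-c2ccc(C(F)(F)F)cc2)nn1` — > 20000 nM

Within the data shown here, in a functional assay on A549 cells (Homo sapiens) for cytotoxicity, read by MTT assay, with a stated time of 4 days (on this read-out lower numbers stand for stronger inhibition and higher numbers for weaker inhibition), compound 2 gives 1260 nM, the only plain number among the three. For compound 1 the result is a limit of the assay, > 20000 nM. For compound 3 the result is likewise a limit, > 20000 nM. Compound 4, `C=C1C(=O)[C@]23C[C@@]1(O)CC[C@H]2c1ccc(O)c(C)c1[C@@H]3Cn1cc(-c2ccc(F)cc2)nn1`, has not yet been measured; it differs from compound 2 by fluoro in place of methyl on an aromatic carbon. Among the measured compounds shown here, no measured pair of compounds differs in this one place alone, so the step has no precedent among the three. A swap of one small group at that place is expected to move this assay little, if at all beyond the scatter. Compound 4 is therefore estimated at 1500 nM, between 500 nM and 5000 nM. The expected step is a 1.2-fold higher number from compound 2 to compound 4 (0.08 log units; within the scatter).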

Compound 4, half-maximal inhibitory concentration: 940 nM
For compound 4 the middle estimate is 1.6-fold (0.20 log units) above the measured one; measured number inside the range.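

In this assay, going from 4-methylphenyl to 4-fluorophenyl gives a 1.3-fold lower number from compound 2 to compound 4 (0.13 log units; within the scatter). Among these compounds, this is the first comparison here of compounds that differ in one place, and it shows that this aromatic carbon, para to a large group, can carry fluoro instead of methyl with no shift beyond the scatter. The other compounds differ in more than one place, and their results are limits, so they add nothing to this reading: the limit of > 20000 nM in this assay, at which 2 of the 4 values shown sit.

As far as these compounds go, it remains open how an amine, a carboxylic acid or a longer chain at this position would read.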